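The source may hold more compounds than are shown below. What is called first, only, known or untested is meant among the compounds shown, and "the series" means these compounds.

Within the data shown here, in a physicochemical assay for lipophilicity (a higher number here means a more lipophilic compound, a lower number a more polar compound), compound 1 `C[n+]1ccn(COCC[Si](C)(C)C)c1/C=N/O` gives -0.34, the higher of the two numbers measured so far. The other measured member, compound 2 `C[n+]1ccn(CCOCCCl)c1/C=N/O`, gives -2.32 in this assay, and the gap between compound 2 and compound 1 lies beyond the usual scatter. Compound 3 `C[n+]1ccn(COCC(C)(C)CBr)c1/C=N/O` has not yet been measured. Relative to compound 1 it carries a group of 5 heavy atoms (4 carbon, 1 bromine; no ring) in place of a group of 5 heavy atoms (4 carbon, 1 silicon; no ring), on a saturated chain carbon bound to an oxygen on a saturated carbon; the rest of the structure, the shared core and the oxime, is unchanged. Among the measured compounds shown here, no step between two measured compounds covers a change of this kind, so nothing measured anchors it. The step from compound 1 to compound 3 is expected to be a number 0.26 log units lower from compound 1 to compound 3 (within the scatter), a small drop or none beyond the scatter. Compound 3 is accordingly estimated to give -0.6 in this assay, with a range from -1.3 to 0.1.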

Compound 3, distribution coefficient: -0.81
The estimate for compound 3 lay 0.21 log units above the measured number; measured number inside the range.
By their numbers in this assay, from the lowest: compound 2; then compound 3; then compound 1.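

Among these compounds, this is the first step that can be read at a single place: in this assay the change gives a number 0.47 log units lower from compound 1 to compound 3 (beyond the scatter) when a group of 5 heavy atoms (4 carbon, 1 bromine; no ring) replaces a group of 5 heavy atoms (4 carbon, 1 silicon; no ring) on a saturated chain carbon bound to an oxygen on a saturated carbon. At this position, the read-out therefore moves, modestly, even though the heavy-atom count, the hydrogen-bond counts and the net charge of the group stay the same. Nothing available bears on why the number moves.

Open, going by these compounds, is how a group ending in chlorine, a hydroxyl or a longer chain would read here in this assay. With a single readable step, no trend can yet be stated for this position.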